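Methoxy to Ethoxy: Expected Toxicity of Compound 4

The source may hold more compounds than are shown below. What is called first, only, known or untested is meant among the compounds shown, and "the series" means these compounds.

Compound 1 `Cc1ccc2[nH]c(=O)c(CN(Cc3ccc(O)cc3)Cc3ccc(C(C)(C)C)cc3)cc2c1` gives 4900 nM in a toxicity assay on MDCK cells (Canis lupus familiaris) for cytotoxicity, read by crystal violet staining, with a stated time of 48 h; on this read-out higher numbers stand for lower toxicity in this test and lower numbers for higher toxicity in this test. Compound 2 `Cc1ccc2[nH]c(=O)c(CN(Cc3ccc(OCC(=O)OC(C)(C)C)cc3)Cc3ccc(C(C)(C)C)cc3)cc2c1` reaches only the limit of > 10000 nM in this assay, a limit and not a number. Compound 3 `COc1ccc(CN(Cc2ccc(C(C)(C)C)cc2)Cc2cc3cc(C)ccc3[nH]c2=O)cc1` likewise reaches only the limit of > 10000 nM in this assay, again a limit and not a number.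

So compound 3 stands at the limit, where (the limit of > 10000 nM in this assay, at which 2 of the 3 values shown sit). Compound 4 `CCOc1ccc(CN(Cc2ccc(C(C)(C)C)cc2)Cc2cc3cc(C)ccc3[nH]c2=O)cc1` differs from compound 3 by methyl in place of hydrogen on a saturated chain carbon bound to an oxygen on an aromatic ring. Going by the values given here, two measured steps bear on this change. Going from the free phenol to the methyl ether gave an at least 2.0-fold higher number from compound 1 to compound 3 (0.30 log units; that floor lies within the scatter). The step between the two ethers, a step that the two limits leave unreadable from compound 2 to compound 3, tells nothing about size, since both ends are limits. A small added methyl on the ether chain gives no reason to expect a reading below the limit. The step that the limit leaves unreadable from compound 3 to compound 4 is therefore expected to be unreadable, with compound 4 most likely returning a limit. The estimate for compound 4 is 15000 nM, within 6000 nM to 40000 nM.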

Compound 4, half-maximal cytotoxic concentration: > 10000 nM
Compound 4 ended at the assay's limit; the forecaster's own chance of this, stated with the estimate: 75%; the middle value does not contradict the limit.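

Ethyl in place of the hydrogen on the oxygen gives an at least 2.0-fold higher number from compound 1 to compound 4 (0.30 log units; that floor lies within the scatter), so a slightly larger ether joins the methyl ether, and the extra methyl does not bring the reading in this assay back to a measurable number. The steps among compound 2, compound 3 and compound 4 cannot be read, as both ends of each are limits. Compound 1, the free phenol, is now the only compound shown with a real number, and the three ethers share one ceiling: the limit of > 10000 nM in this assay, at which 3 of the 4 values shown sit.

From the compounds shown here alone, how far beyond that limit each ether lies remains unknown, so methoxy and ethoxy cannot be ranked against each other. Going by these compounds, whether a longer chain such as propyl, or an amine or a carboxylic acid on the ether chain, would return a measurable number also remains open.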